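Shifting the hydroxyl on one aryl arm of a pyridine core

The source may hold more compounds than are shown below. What is called first, only, known or untested is meant among the compounds shown, and "the series" means these compounds.

The measured compounds:
compound 1 `Oc1ccc(-c2cc(-c3ccccc3F)cc(-c3ccccc3O)n2)cc1`, > 50000 nM (a limit of the assay)
compound 2 `Oc1ccccc1-c1cc(-c2ccccc2C(F)(F)F)cc(-c2ccccc2O)n1`, 4770 nM
compound 3 `Oc1ccccc1-c1cc(-c2ccccc2OC(F)(F)F)cc(-c2ccccc2O)n1`, 5850 nM

In a functional assay on DU-145 cells (Homo sapiens) for inhibition (a lower number here means a stronger inhibitor, a higher number a weaker inhibitor), compound 1 gives only a limit, > 50000 nM. Compound 2 gives 4770 nM and compound 3 gives 5850 nM, the highest of the two numbers. Among the compounds with values here, the only measured step, a 1.2-fold higher number from compound 2 to compound 3 (0.09 log units; within the scatter), is within the scatter, so compound 3 and compound 2 cannot be ordered.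

Compound 4 `Oc1ccc(-c2cc(-c3ccccc3OC(F)(F)F)cc(-c3ccccc3O)n2)cc1` differs from compound 3 by 4-hydroxyphenyl in place of 2-hydroxyphenyl on an aromatic carbon. Within the data shown here, no measured step changes this place, so none bears directly on it. Among the measured compounds shown here, compound 1 is the only measured compound carrying a 4-hydroxyphenyl, and in this assay it shows only a limit; compound 4 is therefore expected to move toward weaker inhibition, with a 5.1-fold higher number from compound 3 to compound 4 (0.71 log units; beyond the scatter) as the estimated step, and a real chance that only a limit is reported. Compound 4 is estimated at 30000 nM, within 8000 nM to 100000 nM.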

Compound 4, half-maximal inhibitory concentration: 4190 nM
Beside the measured number, compound 4's estimate is 7.2-fold (0.85 log units) above it; the whole stated range lies above it.
By their numbers in this assay, from the lowest: compounds 4, 2 and 3 (each within the scatter of the next). At a limit, above all of these: compound 1.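

In this assay, 4-hydroxyphenyl in place of 2-hydroxyphenyl, on the aromatic carbon next to the ring nitrogen, gives a step that stays within the scatter: a 1.4-fold lower number from compound 3 to compound 4 (0.14 log units; within the scatter). The 4-hydroxyphenyl arm therefore does not by itself go with weak inhibition, and the two compounds carrying it are separated by the change on the other arm, trifluoromethoxy in place of fluoro, with an at least 11-fold lower number from compound 1 to compound 4 (1.07 log units; beyond the scatter). That step starts from a limit of the assay rather than a number, so its full size stays unknown: the limit of > 50000 nM in this assay, at which 1 of the 4 values shown sits.

The compounds shown leave open whether a fluoro arm paired with 2-hydroxyphenyl, or a trifluoromethyl arm paired with 4-hydroxyphenyl, would follow the same course. They also leave open how this position responds to an amine or a carboxylic acid in place of the hydroxyl.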